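The compounds below may be only part of what the source reports. "The series", "measured", "known", "first", "only" and "open" are said of these compounds alone.

In an ADME assay on HEK293 cells (Homo sapiens) for cytotoxicity, read by ATP content, with a stated time of 6 h (a lower number here means that less compound is tolerated, a higher number that more compound is tolerated), compound 3 (`COCCNc1nc(N)nc2ccn(Cc3ccccn3)c12`) reads > 24000 nM as a limit of the assay, not a number. Compound 1 (`CCCCNc1nc(N)nc2ccn(Cc3nccs3)c12`) reads > 24000 nM as a limit too. Compound 2 (`CCCCNc1nc(N)nc2ccn(Cc3ccncc3)c12`) reads > 24000 nM as a limit too. All three therefore sit at the same place (the limit of > 24000 nM in this assay, at which 3 of the 3 values shown sit) and none has a true number. Compound 4 (`CC(Nc1nc(N)nc2ccn(Cc3ccccn3)c12)c1ccccn1`) differs from compound 3 on a nitrogen on an aromatic ring (1-(pyridin-2-yl)ethyl in place of 2-methoxyethyl on a nitrogen on an aromatic ring), with 1-(pyridin-2-yl)ethyl in place of 2-methoxyethyl. Among the measured compounds shown here, the one measured step (a step that the two limits leave unreadable from compound 1 to compound 2) swaps a different group at a different place, and its size cannot be read. It therefore offers no size to carry over, and it is only a weak guide here. With every measured compound at the limit, the expected step (a step that the limit leaves unreadable from compound 3 to compound 4) is none beyond the scatter, in either direction. For compound 4 the estimate is 30000 nM with an expected range from 12000 nM to 60000 nM and a good chance that the assay again reports only a limit.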

Compound 4, half-maximal cytotoxic concentration: > 24000 nM
Compound 4: only a limit was reported; the forecaster's own chance of this, stated with the estimate: 75%; the middle value is on the limit's open side.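

In this assay, compound 3 and compound 4 each give only a limit, so no step between them can be read: the limit of > 24000 nM in this assay, at which 4 of the 4 values shown sit.

The compounds shown leave open at what concentration any of them would harm these cells, and whether changing their groups alters that concentration.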